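The source may hold more compounds than are shown below. What is called first, only, known or untested is meant among the compounds shown, and "the series" means these compounds.

Compound 3 `CN1CCC(Cn2c(N)nc3ccc(C(=O)c4ccccc4)cc32)CC1` has been tested in an ADME assay on CRL8155 cells (Homo sapiens) for cytotoxicity, read by resazurin assay, with a stated time of 72 h; a lower number here means that less compound is needed, a higher number that more compound is needed for the effect. In this assay compound 3 gives > 30000 nM, a limit of the assay rather than a measured number. Compound 1 `O=C(c1ccccc1)c1ccc2nc(NCCO)[nH]c2c1` sits at a limit too: in this assay compound 1 gives > 30000 nM. Compound 2 `O=C(CCC1CCNCC1)Nc1nc2ccc(C(=O)c3ccccc3)cc2[nH]1` likewise: in this assay compound 2 gives > 30000 nM. For the measured compounds named here, compound 3 therefore stands where every value so far stands, at the limit of > 30000 nM in this assay, at which 3 of the 3 values shown sit. Compound 4 `CN1CCC[C@@H]1Cn1c(N)nc2ccc(C(=O)c3ccccc3)cc21` is not yet measured and differs from compound 3 in one place: 1-methylpyrrolidin-2-yl in place of 1-methylpiperidin-4-yl on a saturated chain carbon bound to an aromatic nitrogen. Going by the values given here, no measured pair of compounds carries this kind of change, so nothing sets its size. The expectation is no step beyond the scatter, a step that the limit leaves unreadable from compound 3 to compound 4. Compound 4 is thus expected to give 40000 nM, between 15000 nM and 100000 nM, most likely again as a limit.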

Compound 4, half-maximal effective concentration: > 30000 nM
Compound 4 gave a limit, no number; the forecaster's own chance of this, stated with the estimate: 85%; the middle value lies beyond the limit too.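

Compound 3 and compound 4 both give only a limit, so no step between them can be read: the limit of > 30000 nM in this assay, at which 4 of the 4 values shown sit.

The compounds shown leave open whether any change on the shared core would give a measured number rather than a limit.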